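This account rests on a few compounds, and the source may have more. Where it says the series, first, only, none or still open, it means among the compounds named here.

Compound 1, `CN(C)c1ccc(C(=O)Nc2cccc(NC(=O)COc3ccc4c(c3)CCC(=O)N4)c2)cc1`, in an assay on isolated protein for inhibition of Rho-associated protein kinase 1 (Homo sapiens), read by scintillation counting, radiometric assay and 33P incorporation, with a stated time of 40 min, in the presence of a further agent that is not named here (on this read-out lower numbers stand for stronger inhibition and higher numbers for weaker inhibition), gives > 10000 nM, which is a limit of the assay and not a number. Compound 2, `COc1ccc(OCC(=O)Nc2cccc(NC(=O)c3ccc(N(C)C)cc3)c2)cc1OC`, gives > 10000 nM, likewise a limit. Compound 3, `CCc1ccc(C(=O)Nc2cccc(NC(=O)COc3ccc4c(=O)ccoc4c3)c2)cc1`, gives 235 nM.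

Compound 3 therefore holds the only number shown in this assay; the two other values sit at the limit of > 10000 nM in this assay, at which 2 of the 3 values shown sit. Within the data shown here, the single step between measured compounds, a step that the two limits leave unreadable from compound 1 to compound 2, concerns the group on an oxygen on a saturated carbon, a different place, and both limits leave its size unreadable. Compound 4, `O=C(COc1ccc2c(=O)ccoc2c1)Nc1cccc(NC(=O)c2ccc([N+](=O)[O-])cc2)c1`, differs from compound 3 by nitro in place of ethyl on an aromatic carbon. Among the measured compounds shown here, no measured step bears on a change at this place, so the data give no direction for it. For compound 4 the step is expected to stay near the scatter, a 1.3-fold higher number from compound 3 to compound 4 (0.11 log units; within the scatter). Compound 4 is thus estimated at 300 nM, within 100 nM to 1000 nM.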

Compound 4, half-maximal inhibitory concentration: 67 nM
Compound 4: middle estimate off by 4.5-fold (0.65 log units), on the high side; measured number below the stated range.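

In this assay, among these compounds, nitro in place of ethyl on the aromatic carbon gives a 3.5-fold lower number from compound 3 to compound 4 (0.54 log units; beyond the scatter), the first step whose size can be read. It shows that this place, on the 4-ethylphenyl of compound 3, responds to a change of group, and that the 4-nitrophenyl of compound 4 keeps the inhibition. Nothing measured here accounts for the size of this step. Going by these compounds, whether an amine or a carboxylic acid at this place would move the number further remains open. Among the compounds shown here, only this one pair speaks for the change, so whether it carries over to another core is also open.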